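Trifluoromethoxy to Chloro: What to Expect for Compound 3

The compounds below may be only part of what the source reports. "The series", "measured", "known", "first", "only" and "open" are said of these compounds alone.

Measured so far:
Compound 1 `Nc1ccccc1NC(=O)c1ccc(Cn2cnc3c(Nc4ccc(-c5ccccn5)cc4)nc(Cl)nc32)cc1`: 73.7%
Compound 2 `Nc1ccccc1NC(=O)c1ccc(Cn2cnc3c(Nc4cccc(OC(F)(F)F)c4)nc(Cl)nc32)cc1`: 46.6%

In a functional assay on HCT-116 cells (Homo sapiens) for antiproliferative activity, read by CCK-8 assay, with a stated time of 72 h, tested at 8 uM (a lower number here means a weaker effect, a higher number a stronger effect of the compound at the concentration tested), compound 1 gives 73.7%. Within the data shown here, compound 2 gives 46.6% in this assay and so stands lowest of the two numbers; the only measured step is a number 27.1 percentage points lower from compound 1 to compound 2 (beyond the scatter).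

Compound 3 `Nc1ccccc1NC(=O)c1ccc(Cn2cnc3c(Nc4cccc(Cl)c4)nc(Cl)nc32)cc1` differs from compound 2 in one place: chloro in place of trifluoromethoxy on an aromatic carbon. Among the measured compounds shown here, no measured step makes this same exchange. For the measured compounds named here, the single known step, a number 27.1 percentage points lower from compound 1 to compound 2 (beyond the scatter), replaces the whole group on the nitrogen rather than one small group on the ring, so it gives no direct guide to the size or direction of the present change. With nothing to point either way, the step from compound 2 to compound 3 in this assay is expected to stay within the scatter, which is what a number 1.6 percentage points lower from compound 2 to compound 3 (within the scatter) means. Compound 3 is therefore estimated at 45%, within a range from 25% to 65%.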

Compound 3, a percentage reported as inhibition, at one concentration (the size of the read-out at that concentration, not a potency): 78.4%
Compound 3: the middle estimate sits 33.4 percentage points below what was measured; the whole stated range lies below it.
By their numbers in this assay, from the lowest: compound 2; then compounds 1 and 3 (each within the scatter of the next).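

In this assay, one small group on the six-membered aromatic ring of carbon only has a large influence: chloro in place of trifluoromethoxy gives a number 31.8 percentage points higher from compound 2 to compound 3 (beyond the scatter) and so restores the level lost in the earlier step. The larger 4-(pyridin-2-yl)phenyl group is also not required for this level of effect, since 3-chlorophenyl in its place gives a number 4.7 percentage points higher from compound 1 to compound 3 (within the scatter) and the two compounds cannot be told apart here. No measurement is at hand that explains why trifluoromethoxy and chloro differ so much.

Going by these compounds, whether a methoxy group, an amine or a carboxylic acid at this same place would match chloro or trifluoromethoxy remains open. Each number also comes from a single concentration, so how the potencies of these compounds compare is unknown.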